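A few compounds are considered here, and "the series" means these few. Any claim that something is new, unique, unknown or untested is made for them only; others in the source may bear on it.

Measured compounds:
compound 1, `COc1ccccc1-n1nc(C2CC(C)(C)OC(C)(C)C2)cc1-c1ccnc(Cl)c1`, 250 nM
compound 2, `COc1ccccc1-n1nc(C2CC(C)(C)OC(C)(C)C2)cc1-c1ccc(Cl)cc1`, 16 nM
compound 3, `COc1ccccc1-n1nc(C2CC(C)(C)OC(C)(C)C2)cc1-c1ccc(C#N)cc1`, 85 nM

These three share one core and differ only in the aromatic ring that hangs from it. In an assay on HEK293 cells for inhibition of Voltage-dependent N-type calcium channel subunit alpha-1B (Homo sapiens), read by patch clamp, using a membrane potential dye (a higher number here means a weaker inhibitor, a lower number a stronger inhibitor), compound 3 stands second highest of the three numbers: it lies a 2.9-fold lower number from compound 1 to compound 3 (0.47 log units; beyond the scatter), and a 5.3-fold higher number from compound 2 to compound 3 (0.73 log units; beyond the scatter). Compound 4, `COc1ccccc1-n1nc(C2CC(C)(C)OC(C)(C)C2)cc1-c1ccc(C)nc1`, has not yet been measured. It differs from compound 3 in one place: 6-methylpyridin-3-yl in place of 4-cyanophenyl on an aromatic carbon.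

Among the measured compounds shown here, two measured steps bear on this change, since both replace a pyridine ring with a benzene ring: a 16-fold lower number from compound 1 to compound 2 (1.19 log units; beyond the scatter) and a 2.9-fold lower number from compound 1 to compound 3 (0.47 log units; beyond the scatter). In both, moving away from a pyridine gave a lower number; compound 4 moves back to a pyridine, although with a methyl group rather than a chloro group and with the ring nitrogen in a different place. The step in this assay is therefore expected to go upward, of modest size, a 2.4-fold higher number from compound 3 to compound 4 (0.37 log units; beyond the scatter). Compound 4 is estimated at 200 nM, with a range from 60 nM to 700 nM.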

Compound 4, half-maximal inhibitory concentration: 13000 nM
The estimate for compound 4 lay 65-fold (1.81 log units) below the measured number; the whole stated range lies below it.
By their numbers in this assay, from the lowest: compound 2; then compound 3; then compound 1; then compound 4.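

A pyridine ring at this position is not merely a modest penalty in this assay: replacing 4-cyanophenyl with 6-methylpyridin-3-yl gives a 150-fold higher number from compound 3 to compound 4 (2.18 log units; beyond the scatter), and replacing 4-chlorophenyl gives an 810-fold higher number from compound 2 to compound 4 (2.91 log units; beyond the scatter). Compounds 1 and 4 both carry a pyridine ring, yet they are far apart, with a 52-fold higher number from compound 1 to compound 4 (1.72 log units; beyond the scatter), so the presence of a ring nitrogen alone does not fix the number; which pyridine sits here, and what it carries, matters greatly. Nothing available explains this sharp loss.

The compounds shown do not separate the contribution of the methyl group from that of the ring nitrogen's place. A plain phenyl ring, or a pyridine ring bearing chloro in place of the methyl of compound 4, would help to tell these apart.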